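A few compounds are considered here, and "the series" means these few. Any claim that something is new, unique, unknown or untested is made for them only; others in the source may bear on it.

Compound 1 `Cc1c(C(=O)Nc2ccc(C(F)(F)F)cc2)cnn1-c1ccc(F)c(Cl)c1` gives 1300 nM in a functional assay with Homo sapiens as the target; a higher number here means a weaker inhibitor, a lower number a stronger inhibitor.
Compound 2 `Cc1ccc(NC(=O)c2cnn(-c3ccc(F)cc3)c2C)cc1` gives 540 nM in this assay.
Compound 3 `Cc1c(C(=O)Nc2cccc(F)c2)cnn1-c1ccc(F)cc1` gives 3000 nM in this assay.

All three compounds share the same core, an amide linking a substituted ring to a ring that carries a methyl group; they differ in the groups on the two outer rings. Compound 3 stands at the top of the three numbers, which makes it the weakest inhibitor here: its gap to compound 1 and its gap to compound 2 both lie beyond the scatter.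

Compound 4 `COc1cccc(NC(=O)c2cnn(-c3ccc(F)cc3)c2C)c1` has not yet been measured in this assay. It differs from compound 3 in a single place: methoxy in place of fluoro on an aromatic carbon.

Within the data shown here, one measured step bears on this kind of change, because it alters the same ring on the amide-type nitrogen: a 5.6-fold higher number from compound 2 to compound 3 (0.74 log units; beyond the scatter). Among the measured compounds shown here, that step shows that a change on this ring can move the number well beyond the scatter, but no measured pair shows methoxy in place of fluoro directly, so its direction remains open. A small lowering of the number is therefore expected for compound 4, about a 2.0-fold lower number from compound 3 to compound 4 (0.30 log units; within the scatter), with wide uncertainty. The estimate for compound 4 in this assay is 1500 nM, within a range of 500 nM to 5000 nM.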

Compound 4, half-maximal inhibitory concentration: 3700 nM
The estimate for compound 4 lay 2.5-fold (0.39 log units) below the measured number, within the range that was stated.
By their numbers in this assay, from the lowest: compound 2; then compound 1; then compounds 3 and 4 (each within the scatter of the next).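

Replacing fluoro with methoxy on this aromatic carbon, meta to a large group, gives a 1.2-fold higher number from compound 3 to compound 4 (0.09 log units; within the scatter), so the two groups cannot be told apart in this assay, even though methoxy is counted with a hydrogen-bond acceptor and fluoro is not. Both of these rings also fall well short of the 4-methylphenyl ring, with a 5.6-fold higher number from compound 2 to compound 3 (0.74 log units; beyond the scatter) for the 3-fluorophenyl ring and a 6.9-fold higher number from compound 2 to compound 4 (0.84 log units; beyond the scatter) for the 3-methoxyphenyl ring, and each of these steps lies beyond the scatter. No measurement shown here offers an explanation for either the flat result at this position or the larger steps.

A group such as an amine or a carboxylic acid in this same place could still move the number, so the flat result covers only fluoro and methoxy. Also open, on these data alone, is whether the advantage of compound 2 comes from the methyl group itself or from where it sits on the ring, since the two steps from that compound change both at once.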